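Swapping the aryl group on the triazole of a spiro core

This account rests on a few compounds, and the source may have more. Where it says the series, first, only, none or still open, it means among the compounds named here.

Compound 3 `N#CC1=C(N)Oc2c(N)cc3nc4ccccc4nc3c2C12C(=O)N(Cc1cnnn1-c1ccccc1Br)c1ccccc12` is the only one of the three measured compounds to give a number in a functional assay on HepG2 cells (Homo sapiens) for antiproliferative activity, read by MTT assay, with a stated time of 48 h (a higher number here means a weaker inhibitor, a lower number a stronger inhibitor), where compound 3 reaches 38000 nM. Compound 1 `N#CC1=C(N)Oc2c(c3nc4ccccc4nc3c3ccccc23)C12C(=O)N(Cc1cnnn1-c1ccc(Cl)cc1)c1ccccc12` gives only a limit of the assay in this assay, namely > 50000 nM. Compound 2 `Cc1ccc(-n2nncc2CN2C(=O)C3(C(C#N)=C(N)Oc4c3c3nc5ccccc5nc3c3ccccc43)c3ccccc32)c(C)c1` likewise gives only a limit in this assay, namely > 50000 nM. The evidence on aryl swaps is thin: the limit of > 50000 nM in this assay, at which 2 of the 3 values shown sit, so the change of a step that the two limits leave unreadable from compound 1 to compound 2 cannot be read as larger or smaller than the scatter.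

Compound 4 `Cc1ccc(-n2nncc2CN2C(=O)C3(C(C#N)=C(N)Oc4c(N)cc5nc6ccccc6nc5c43)c3ccccc32)cc1C` differs from compound 3 by 3,4-dimethylphenyl in place of 2-bromophenyl on an aromatic nitrogen. The most comparable change, that from compound 1 to compound 2, stays unreadable, so no direction is supported by the numbers shown. Compound 4 is therefore expected to stay close to compound 3, with a step of a 1.2-fold higher number from compound 3 to compound 4 (0.07 log units; within the scatter) that lies within the scatter, and an estimate of 45000 nM, between 20000 nM and 100000 nM, where it may well sit at the limit again.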

Compound 4, half-maximal inhibitory concentration: > 50000 nM
Compound 4 gave a limit, no number; the forecaster's own chance of this, stated with the estimate: 50%; middle value at least 1.1-fold (0.04 log units) away from the limit.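

Compared with the step from compound 1 to compound 2, which could not be read, this pair gives the first step at this position with a number at one end: an at least 1.3-fold higher number from compound 3 to compound 4 (0.11 log units; that floor lies within the scatter) in this assay. Exchanging 2-bromophenyl for 3,4-dimethylphenyl on the aromatic nitrogen therefore sets a floor for the change, but that floor does not separate the pair from ordinary scatter. The true size of the step remains unknown, and the assay limit now dominates the set: the limit of > 50000 nM in this assay, at which 3 of the 4 values shown sit.

From the compounds shown here alone, it remains open how far the step extends past its floor, since only compound 3 has a number. Also open, going by these compounds, is how this position would respond to a pyridyl ring or to a phenyl ring bearing a carboxylic acid or an amine.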